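The source may hold more compounds than are shown below. What is called first, only, known or untested is meant among the compounds shown, and "the series" means these compounds.

Compounds measured so far:

Compound 1, `COc1ccc(OC)c(/C=C/c2nnc(Nc3ccc(Cl)cc3)o2)c1`, gives 20700 nM in a functional assay on M14 cells (Homo sapiens) for antiproliferative activity, read by sulforhodamine B assay, with a stated time of 48 h; a higher number here means a weaker inhibitor of growth, a lower number a stronger inhibitor of growth.
Compound 2, `COc1ccc(OC)c(/C=C/C(=O)N/N=C/c2ccc(Cl)cc2)c1`, gives 87.9 nM in this assay.

Compound 2 stands at the lowest of the two numbers available. Its nearest neighbour is compound 1, whose number is far higher, a gap well beyond the scatter; the two compounds differ in more than one place, so nothing more than this contrast can be drawn from them.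

The step under consideration leads from compound 2 to compound 3, `COc1ccc(OC)c(/C=C/C(=O)N/N=C/c2ccccc2)c1`. The change is hydrogen in place of chloro on an aromatic carbon. Within the data shown here, no measured pair shows this change on its own, so there is no step from the data to lean on. A change this small on the outer ring is expected to move the number only modestly, most likely toward a somewhat higher value, though a result within the scatter of compound 2 would not surprise.

Compound 3 is therefore estimated at 160 nM, with a range from 50 nM to 500 nM. The expected step from compound 2 to compound 3 is a 1.8-fold higher number from compound 2 to compound 3 (0.26 log units; within the scatter).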

Compound 3, concentration for 50% growth inhibition: 2160 nM
For compound 3 the middle estimate is 14-fold (1.13 log units) below the measured one; measured number above the stated range.
By their numbers in this assay, from the lowest: compound 2; then compound 3; then compound 1.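

In this assay, among these compounds, the change from 4-chlorophenyl to phenyl gives a 25-fold higher number from compound 2 to compound 3 (1.39 log units; beyond the scatter), and this is the first comparison here in which only one place differs. It shows that this position, on an aromatic carbon and para to a large group, is far from indifferent: with all else the same, the lower number of compound 2 depends heavily on the chloro group, and a single heavy atom accounts for the whole step. No information on hand explains why one chlorine atom has so large an effect.

The compounds shown leave open whether chloro is special at this position or whether fluoro, bromo, methyl, methoxy or an amine in its place would hold the number near that of compound 2 or let it rise toward that of compound 3. They also leave open whether a chloro group elsewhere on the same ring would give a comparable step, and whether the step seen here would recur on a different core.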